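Swapping Methylsulfanyl for Phenoxy on a Shared Core

The source may hold more compounds than are shown below. What is called first, only, known or untested is meant among the compounds shown, and "the series" means these compounds.

Of the compounds shown here, three have so far been measured in a functional assay for inhibition of sodium/hydrogen exchanger (Oryctolagus cuniculus); a lower number here means a stronger inhibitor, a higher number a weaker inhibitor. Compound 1 `Cc1c(C(=O)N=C(N)N)cc(S(C)(=O)=O)c(Cl)c1C` gives 58 nM, compound 2 `Cc1cc(-c2ccc(F)cc2)c(S(C)(=O)=O)cc1C(=O)N=C(N)N` gives 36 nM, and compound 3 `CSc1cc(C)c(C(=O)N=C(N)N)cc1S(C)(=O)=O` gives 6 nM. Compound 3 holds the lowest of the three numbers; compound 2 is its nearest neighbour and compound 1 the furthest, and both gaps lie beyond the usual scatter. Compound 4 `Cc1cc(Oc2ccccc2)c(S(C)(=O)=O)cc1C(=O)N=C(N)N` has not yet been measured. It differs from compound 3 in a single place: phenoxy in place of methylsulfanyl on an aromatic carbon. For the measured compounds named here, only one measured step bears on this change. Within the same core, putting methylsulfanyl in place of 4-fluorophenyl on an aromatic carbon gave a 6.0-fold lower number from compound 2 to compound 3 (0.78 log units; beyond the scatter). Compound 4 returns a ring-bearing group to that aromatic carbon, so in this assay a step back in the opposite direction, of roughly similar size, is expected. The estimate for compound 4 is 28 nM, with a range from 9 nM to 90 nM. This estimate means an expected step of a 4.7-fold higher number from compound 3 to compound 4 (0.67 log units; beyond the scatter).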

Compound 4, half-maximal inhibitory concentration: 10 nM
For compound 4 the middle estimate is 2.8-fold (0.45 log units) above the measured one; the range from low to high includes it.
By their numbers in this assay, from the lowest: compounds 3 and 4 (each within the scatter of the next); then compounds 2 and 1 (each within the scatter of the next).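

In this assay, a ring-bearing group on this aromatic carbon does not by itself raise the number: phenoxy and methylsulfanyl cannot be told apart, with a 1.7-fold higher number from compound 3 to compound 4 (0.22 log units; within the scatter) lying inside the usual scatter. The loss seen with 4-fluorophenyl therefore does not extend to every ring-bearing group, as a 3.6-fold lower number from compound 2 to compound 4 (0.56 log units; beyond the scatter) separates two such groups by more than the scatter. Phenoxy and 4-fluorophenyl differ in both the oxygen link and the fluorine, and this single comparison cannot assign the step to either one. No measurement on hand gives a reason for these results. Plain phenyl and 4-fluorophenoxy on this carbon would be the groups to separate those two features, and it remains open whether an amine there would fit the same picture.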